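Saturated-ring substituent change toward a triazole analogue

A few compounds are considered here, and "the series" means these few. Any claim that something is new, unique, unknown or untested is made for them only; others in the source may bear on it.

The series shares one core and varies the group on a saturated ring carbon of a six-membered non-aromatic ring of carbon only. Compound 1 `CO[C@H]1CC[C@@H](Nc2cc(NCc3cnccc3C(F)(F)F)ncc2C#N)CC1` carries methoxy there, and in an assay on isolated protein for inhibition of protein kinase C delta type (Homo sapiens), read by TR-FRET, with a stated time of 2 h (a higher number here means a weaker inhibitor, a lower number a stronger inhibitor), compound 1 gives 5000 nM. Compound 2 `N#Cc1cnc(NCc2cnccc2C(F)(F)F)cc1N[C@H]1CC[C@@H](C(N)=O)CC1` carries carbamoyl; in this assay compound 2 gives 400 nM. Compound 3 `CNC(=O)[C@H]1CC[C@@H](Nc2cc(NCc3cnccc3C(F)(F)F)ncc2C#N)CC1` carries methylcarbamoyl; in this assay compound 3 gives 1600 nM, the second highest of the three numbers, with compound 1 nearest and compound 2 furthest.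

Compound 4 `N#Cc1cnc(NCc2cnccc2C(F)(F)F)cc1N[C@H]1CC[C@@H](c2nc[nH]n2)CC1` differs from compound 3 by 1H-1,2,4-triazol-3-yl in place of methylcarbamoyl on a saturated ring carbon. Among the compounds with values here, three measured steps bear on this. Replacing methoxy by a group carrying one hydrogen-bond donor lowered the number in both cases, a 13-fold lower number from compound 1 to compound 2 (1.10 log units; beyond the scatter) and a 3.1-fold lower number from compound 1 to compound 3 (0.49 log units; beyond the scatter), while a 4.0-fold higher number from compound 2 to compound 3 (0.60 log units; beyond the scatter) shows that the methyl on the amide-type nitrogen raised it. The entering group keeps one hydrogen-bond donor and has two acceptors, which places it closer to compound 2 than to compound 3 on these counts. A step down from compound 3 is therefore expected, of a size between the two earlier steps from compound 1. For compound 4 the expected step is a 3.2-fold lower number from compound 3 to compound 4 (0.51 log units; beyond the scatter). Compound 4 is estimated in this assay at 500 nM, with a range from 150 nM to 2000 nM.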

Compound 4, half-maximal inhibitory concentration: 1200 nM
Estimate against measurement, compound 4: 2.4-fold (0.38 log units) below; measured number inside the range.
By their numbers in this assay, from the lowest: compound 2; then compounds 4 and 3 (each within the scatter of the next); then compound 1.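

In this assay, putting 1H-1,2,4-triazol-3-yl in place of methylcarbamoyl on the saturated ring carbon gives a 1.3-fold lower number from compound 3 to compound 4 (0.12 log units; within the scatter), so this assay does not separate these two groups, although one is an open-chain amide and the other a five-membered aromatic ring with 3 hetero atoms. The triazole does not match carbamoyl, with a 3.0-fold higher number from compound 2 to compound 4 (0.48 log units; beyond the scatter), so keeping the hydrogen-bond donor and adding an acceptor does not by itself reproduce the number of compound 2, which remains the lowest of the four. Against methoxy the triazole gives a 4.2-fold lower number from compound 1 to compound 4 (0.62 log units; beyond the scatter), making compound 4 the third of three compounds, with compound 2 and compound 3, whose group at this position carries a hydrogen-bond donor and whose number is lower than that of compound 1, with no compound shown going against this.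

Nothing on hand accounts for any of these steps. From the compounds shown here alone, whether a primary amine, a carboxylic acid or a longer chain ending in carbamoyl at this ring carbon would come closer to compound 2 remains open.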